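From a Methoxybenzyl Group to a Phenylpropyl Chain

This account rests on a few compounds, and the source may have more. Where it says the series, first, only, none or still open, it means among the compounds named here.

Compound 1 `COc1ccccc1CNc1nc2c(N)ncnc2n1[C@@H]1O[C@H](CO)[C@@H](O)[C@H]1O` was examined in an assay on COS-7 cells for inhibition of sodium/nucleoside cotransporter 2 (Homo sapiens), read by scintillation counting, in the presence of a further agent that is not named here; on this read-out higher numbers stand for weaker inhibition and lower numbers for stronger inhibition. In this assay compound 1 gives only a limit, > 100000 nM. Compound 3 `CCOC(=O)OC[C@H]1O[C@@H](n2cnc3c(N)ncnc32)[C@H](O)[C@@H]1O` likewise gives only a limit in this assay, > 100000 nM. Compound 2 `Nc1ncnc2c1nc(NCc1ccc(-c3ccccc3)cc1)n2[C@@H]1O[C@H](CO)[C@@H](O)[C@H]1O` gives a number in this assay, 640 nM. Compound 1 therefore stands together with compound 3 at the limit of > 100000 nM in this assay, at which 2 of the 3 values shown sit, while compound 2 alone shows measurable inhibition. Compound 4 `Nc1ncnc2c1nc(NCCCc1ccccc1)n2[C@@H]1O[C@H](CO)[C@@H](O)[C@H]1O` has not yet been measured; it differs from compound 1 by phenethyl in place of 2-methoxyphenyl on a saturated chain carbon bound to a nitrogen on an aromatic ring. Within the data shown here, no measured pair shows this change. Given that compound 2 gives 640 nM, compound 4 is expected to show measurable inhibition, with the step of an at least 10-fold lower number from compound 1 to compound 4 (1.00 log units; beyond the scatter) reaching beyond the scatter. The estimate for compound 4 is 10000 nM, between 1000 nM and 100000 nM.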

Compound 4, half-maximal inhibitory concentration: 536000 nM
Compound 4: the middle estimate sits 54-fold (1.73 log units) below what was measured; the measured number lies above the stated range.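

In this assay compound 1 gives only a limit, > 100000 nM, so the step to compound 4 cannot be read. Going by these compounds, whether 3-phenylpropyl in place of 2-methoxybenzyl strengthens or weakens inhibition stays open.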